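A few compounds are considered here, and "the series" means these few. Any claim that something is new, unique, unknown or untested is made for them only; others in the source may bear on it.

Measured so far in an assay on isolated protein for binding affinity to corticotropin-releasing factor receptor 1 (Homo sapiens); a higher number here means a weaker inhibitor, a lower number a stronger inhibitor:
compound 1 `CC(=O)/C(=N\c1ccc(Cl)cc1)NNc1ccccc1C` gives 1830 nM
compound 2 `CC(=O)/C(=N\c1cccc(F)c1)NNc1ccccc1C` gives 43 nM

Among the compounds with values here, compound 1 gives the higher of the two numbers; the only other measured compound is compound 2, and the step of a 43-fold lower number from compound 1 to compound 2 (1.63 log units; beyond the scatter) is large and beyond the scatter. That step exchanges the aryl on the double-bonded nitrogen, 3-fluorophenyl in place of 4-chlorophenyl.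

Compound 3 `CC(=O)/C(=N\c1ccc(Cl)cc1)NNc1ccccc1Cl` differs from compound 1 elsewhere: chloro in place of methyl on an aromatic carbon, which read one bond further out is 2-methylphenyl to 2-chlorophenyl. Within the data shown here, no measured step touches this part of the molecule, so the single large step seen in this assay does not bear on the change at hand. Among the measured compounds shown here, with no measured step for or against a shift, the expectation in this assay is a step that stays within the scatter. Compound 3 is therefore estimated at 1500 nM, with a range of 450 nM to 5000 nM. The expected step of a 1.2-fold lower number from compound 1 to compound 3 (0.09 log units; within the scatter) is one that would not be distinguished from repeat measurement.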

Compound 3, inhibition constant: 3870 nM
For compound 3 the middle estimate is 2.6-fold (0.41 log units) below the measured one; low and high end bracket the measured number.
By their numbers in this assay, from the lowest: compound 2; then compound 1; then compound 3.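

In this assay, the aromatic carbon ortho to a large group proves responsive to substitution: chloro in place of methyl gives a 2.1-fold higher number from compound 1 to compound 3 (0.33 log units; beyond the scatter). The shift is modest but beyond the scatter, so the 2-methylphenyl end of the molecule also moves the number, at least with 4-chlorophenyl kept on the double-bonded nitrogen. No supporting measurement bears on the reason for this step.

On these data alone, it remains open whether chloro in place of methyl gives a step of similar size and direction with the 3-fluorophenyl group of compound 2. Also open, as far as these compounds go, is how a methoxy group, an amine or plain hydrogen on the same aromatic carbon would read in this assay, and so whether methyl and chloro are representative of this position.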